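From Fluoro to Bromo in a Cytotoxicity Series

The source may hold more compounds than are shown below. What is called first, only, known or untested is meant among the compounds shown, and "the series" means these compounds.

Compound 1 `O=Cc1cn(Cc2ccc(Cl)cc2Cl)c2ccccc12` with 100 nM
Compound 2 `O=Cc1cn(Cc2ccc(Cl)cc2)c2ccc(F)cc12` with 290 nM
Compound 3 `O=Cc1cn(Cc2ccc(Cl)cc2)c2cc(F)ccc12` with 120 nM

In a functional assay on NCI-H460 cells (Homo sapiens) for cytotoxicity, read by sulforhodamine B assay, with a stated time of 3 days (on this read-out higher numbers stand for weaker inhibition and lower numbers for stronger inhibition), compound 3 stands at 120 nM and lies within the scatter of compound 1 at 100 nM so no order can be drawn between those two. Compound 2 at 290 nM lies beyond the scatter from compound 3 and carries the higher number.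

Compound 4 `O=Cc1cn(Cc2ccc(Cl)cc2)c2cc(Br)ccc12` has not yet been measured. It differs from compound 3 by a single swap, bromo in place of fluoro on an aromatic carbon and that carbon is meta to a fused ring and para to a fused ring. Among the measured compounds shown here, no measured pair here differs in one place only, so the data offer no direct step for this swap. The expectation rests on the narrow spread of the series, in which compound 3 at 120 nM and compound 1 at 100 nM stay within the scatter although their structures differ in more than one place. Compound 2 at 290 nM goes against that picture. The estimated change is a 1.1-fold lower number from compound 3 to compound 4 (0.04 log units; within the scatter) and no step beyond the scatter is expected in either direction. Compound 4 is estimated at 110 nM in this assay with 45 nM to 270 nM as the expected range.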

Compound 4, half-maximal inhibitory concentration: 90 nM
Beside the measured number, compound 4's estimate is 1.2-fold (0.09 log units) above it, within the range that was stated.
By their numbers in this assay, from the lowest: compounds 4, 1 and 3 (each within the scatter of the next); then compound 2.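

In this assay, among the compounds shown here, bromo in place of fluoro on this aromatic carbon, meta to a fused ring and para to a fused ring, gives the first step that changes one place only: a 1.3-fold lower number from compound 3 to compound 4 (0.12 log units; within the scatter). The earlier compounds shown here differed from one another in more than one place, so they could not show what a change at this carbon alone does; here, the exchange of one halogen for the other leaves the read-out within the scatter, and no order can be drawn between the pair. Nothing measured alongside these compounds offers an explanation for this result.

The only groups shown on this carbon in the pair are fluoro and bromo, so it remains open whether an amine, a carboxylic acid or a methoxy group would keep the number in the same range. As far as these compounds go, it also remains open whether bromo in place of fluoro would give a similar step on the other ring carbon, where compound 2 carries its fluoro.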